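The source may report more compounds than this note shows. Statements on the series, on what has been measured and on what is new or still open speak of the compounds shown alone.

Measured in a physicochemical assay for lipophilicity, using the shake flask method, measured as octanol-water partition, at pH 7.4 (a higher number here means a more lipophilic compound, a lower number a more polar compound), so far:
- compound 1 `CNC(=O)CN1CCC(c2cc3c(-c4ccc(=O)n(C(C)C)c4)ccnc3[nH]2)CC1` gives 2.2
- compound 2 `CC(=O)N1CCC(c2cc3c(-c4ccc(=O)n(C(C)C)c4)ccnc3[nH]2)CC1` gives 2.1

Compound 2 and compound 1 lie within the scatter of each other, so the two numbers give no ordering. The next step leads to compound 3 `CC(C)n1cc(-c2ccnc3[nH]c(C4CCN(CC(=O)N5CCCC5)CC4)cc23)ccc1=O` and is described by ((pyrrolidin-1-yl)carbonyl)methyl in place of acetyl on an amine nitrogen in a ring as its structural change. In words, ((pyrrolidin-1-yl)carbonyl)methyl stands in place of acetyl on an amine nitrogen in a ring.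

Within the data shown here, one measured step bears on this: a number 0.10 log units lower from compound 1 to compound 2 (within the scatter) at the same place, with acetyl in place of (methylcarbamoyl)methyl. That step stays within the scatter, so exchange at this nitrogen has not yet moved the number measurably in the two compounds at hand. It is also thin evidence. Among the measured compounds shown here, no measured compound carries the entering five-membered ring, and the data hold no direct step for it.

A modest rise is therefore expected rather than a large one, and the estimated step is a number 0.50 log units higher from compound 2 to compound 3 (beyond the scatter) in this reading. In this assay compound 3 is expected at 2.6 within an estimated range of 2.1 to 3.1 as a working figure.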

Compound 3, distribution coefficient: 2.1
For compound 3 the middle estimate is 0.50 log units above the measured one; low and high end bracket the measured number.
By their numbers in this assay, from the lowest: compounds 2, 3 and 1 (each within the scatter of the next).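

In this assay, the exchange of acetyl, with its 3 heavy atoms, for ((pyrrolidin-1-yl)carbonyl)methyl, with 8 heavy atoms and one five-membered non-aromatic ring, gives no change at the digits printed from compound 2 to compound 3 (within the scatter), so this much larger group on the amine nitrogen in a ring leaves no measurable shift at this position. The comparison within the carbonyl-bearing side chain gives a number 0.10 log units lower from compound 1 to compound 3 (within the scatter), showing that pyrrolidin-1-yl in place of methylamino on a carbonyl carbon also stays inside the scatter, and the three compounds now give no ordering among them. No measurement at hand accounts for this flat outcome.

On these data alone, all three groups on this nitrogen carry a carbonyl, so it remains open whether a carboxylic acid, a 2-(dimethylamino)ethyl chain or a plain longer alkyl chain at the same place would separate from compound 2, compound 3 and compound 1 in this assay. As far as these compounds go, it is also open whether these same exchanges would stay within the scatter on a core other than the shared core.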